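This account rests on a few compounds, and the source may have more. Where it says the series, first, only, none or still open, it means among the compounds named here.

Working notes on the series, read in a physicochemical assay for solubility, read by HPLC, measured as kinetic solubility; a higher number here means a more soluble compound, a lower number a less soluble compound. Compound 1 `NC(=O)c1cc(-c2ccccc2)cc2c(C3CCN(S(=O)(=O)CCCN4CCCCC4)CC3)c[nH]c12` gives 162000 nM and compound 2 `NC(=O)c1cc(-c2ccccc2)cc2c(C3CCS(=O)(=O)CC3)c[nH]c12` gives 130000 nM in this read-out. Among the measured compounds shown here, these two numbers lie within the scatter of each other, so compound 1 cannot be placed in any order against the only other measured compound. For the measured compounds named here, the two compounds share a core but differ in more than one place, and no measured pair differing in one place is available. The data therefore give no direct measure of what a single change does here.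

The next compound is compound 3 `CCN(CC)CCCS(=O)(=O)N1CCC(c2c[nH]c3c(C(N)=O)cc(-c4ccccc4)cc23)CC1`. Its change from compound 1 is diethylamino in place of piperidin-1-yl on a saturated chain carbon, three bonds along the chain from a sulfonyl sulfur, on a saturated chain carbon, three bonds along the chain from a sulfonyl sulfur. Going by the values given here, with no measured step to guide it, the expectation in this assay starts from compound 1 at 162000 nM and favours no direction. The estimated step of a 1.0-fold lower number from compound 1 to compound 3 (0.02 log units; within the scatter) is expected to stay within the scatter. For compound 3 the estimate is 155000 nM, with an expected range of 90000 nM to 210000 nM when measured.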

Compound 3, solubility: 173000 nM
Beside the measured number, compound 3's estimate is 1.1-fold (0.05 log units) below it; the measured number falls inside the stated range.
By their numbers in this assay, from the lowest: compounds 2, 1 and 3 (each within the scatter of the next).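

In this assay, among the compounds shown here, the step of a 1.1-fold higher number from compound 1 to compound 3 (0.03 log units; within the scatter) is the first direct reading of a single change, which the earlier pair of compounds, differing in more than one place, could not give. On a saturated chain carbon, three bonds along the chain from a sulfonyl sulfur, replacing the ring of piperidin-1-yl with the ring-free diethylamino leaves the read-out within the scatter, so for this one pair, closing or opening the ring makes no readable difference. No supporting evidence bears on this result.

The compounds shown leave open whether this flat reading holds for a group of a different kind at the same place, such as morpholin-4-yl, a primary amine or a carboxylic acid, since both groups read so far are uncharged in the computed comparison and each carries a single nitrogen. They also leave open what a shorter or longer chain would do with either amine kept in place, and how much of the read-out depends on the amine at all, as compound 2 differs from compound 1 in more than one place.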